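Adding a Methyl Group on a Tryptic Peptide Amide

The compounds below may be only part of what the source reports. "The series", "measured", "known", "first", "only" and "open" are said of these compounds alone.

Measured so far:
- compound 1, `C[C@](NC(=O)[C@H](CCCCN)NC(=O)[C@H](CCCNC(=N)N)NC(=O)c1ccccc1)(C(N)=O)c1ccccc1`: 11.8%
- compound 2, `CN(C(=O)c1ccccc1)[C@@H](CCCNC(=N)N)C(=O)N[C@@H](CCCCN)C(=O)N[C@@H](C(N)=O)c1ccccc1`: <= 5%

Both compounds were tested in an assay on isolated protein for inhibition of Trypsin (Homo sapiens), read by fluorescence, with a stated time of 15 min, tested at 50 uM; on this read-out higher numbers stand for more inhibition at the one concentration tested (going by the name of the read-out) and lower numbers for less inhibition. In this assay compound 1 gives 11.8%, a modest reading. Compound 2 reaches only <= 5%, and this is a limit of the assay rather than a number: the inhibition did not rise above it. Where compound 2 truly stands is therefore known only as a range, from no inhibition up to that limit, as the line the limit of <= 5% in this assay, at which 1 of the 2 values shown sits, notes.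

Compound 3, `CN(C(=O)c1ccccc1)[C@@H](CCCNC(=N)N)C(=O)N[C@@H](CCCCN)C(=O)N[C@@](C)(C(N)=O)c1ccccc1`, has not yet been tested. It is derived from compound 2 by a single structural change, (1-carbamoyl-1-phenylethyl in place of carbamoyl(phenyl)methyl on an amide-type nitrogen). Within the data shown here, since there is no measured pair in this set that differs in exactly this way, the size of the step cannot be read from the data. The change is small, and with compound 2 sitting at a limit, the expected step of a number at least 3 percentage points higher from compound 2 to compound 3 (that floor lies within the scatter) is, if anything, a minor rise that stays within the usual scatter. Compound 3 is thus expected to give about 8%, most plausibly between 0% and 20%.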

Compound 3, a percentage reported as inhibition, at one concentration (the size of the read-out at that concentration, not a potency): 10.9%
The estimate for compound 3 lay 2.9 percentage points below the measured number, within the range that was stated.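

In this assay, among these compounds, putting 1-carbamoyl-1-phenylethyl in place of carbamoyl(phenyl)methyl on an amide-type nitrogen gives the first reading for this change: a number at least 5.9 percentage points higher from compound 2 to compound 3 (that floor lies within the scatter). That figure is only a floor and not the true size of the step, because compound 2 sits at a limit of the assay: the limit of <= 5% in this assay, at which 1 of the 3 values shown sits.

The second new step concerns the methyl in place of hydrogen on an amide-type nitrogen, and it reads a number 0.9 percentage points lower from compound 1 to compound 3 (within the scatter), so with 1-carbamoyl-1-phenylethyl present, this methyl leaves compound 1 and compound 3 indistinguishable on this read-out.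

The compounds shown leave open whether the same methyl on that nitrogen would matter with carbamoyl(phenyl)methyl in place, since no compound here pairs that group with the amide hydrogen. They also leave open whether an ethyl group in place of the new methyl, or a carboxylic acid in place of the carbamoyl group, would move the inhibition clearly beyond the modest readings seen so far.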